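Compound 4 and the Limit of Compound 3

The source may report more compounds than this note shows. Statements on the series, on what has been measured and on what is new or still open speak of the compounds shown alone.

Measured in a functional assay on A549 cells (Homo sapiens) for antiproliferative activity, read by MTT assay; a lower number here means a stronger inhibitor, a higher number a weaker inhibitor:
Compound 1 `O=C1NC(c2ccccc2)CN1S(=O)(=O)c1ccc2c(c1)CCCN2`: > 20000 nM (a limit)
Compound 2 `CCCOC(=O)N1CCCc2cc(S(=O)(=O)N3CC(c4ccccc4)NC3=O)ccc21`: 1030 nM
Compound 3 `CCCCOC(=O)N1CCCc2cc(S(=O)(=O)N3CC(c4ccccc4)NC3=O)ccc21`: > 20000 nM (a limit)

Compound 3 stands at a limit, not at a number: > 20000 nM. It shares that place with one other compound: the limit of > 20000 nM in this assay, at which 2 of the 3 values shown sit. Compound 4 `NC(=O)N1CCCc2cc(S(=O)(=O)N3CC(c4ccccc4)NC3=O)ccc21` carries amino in place of butoxy on a carbonyl carbon. For the measured compounds named here, two measured steps bear on this change, both large and opposite in direction. Propoxycarbonyl in place of hydrogen gave an at least 19-fold lower number from compound 1 to compound 2 (1.28 log units; beyond the scatter), and methyl on the chain end gave an at least 19-fold higher number from compound 2 to compound 3 (1.28 log units; beyond the scatter). Compound 2 at 1030 nM shows that a group on this carbonyl can give a measurable number. A lower number is therefore expected, as an estimated at least 2.2-fold lower number from compound 3 to compound 4 (0.34 log units; beyond the scatter). For compound 4 the estimate is 9000 nM, with an expected range of 1500 nM to 20000 nM.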

Compound 4, half-maximal inhibitory concentration: 2540 nM
Beside the measured number, compound 4's estimate is 3.5-fold (0.55 log units) above it; the measured number falls inside the stated range.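

Carbamoyl in place of hydrogen gives an at least 7.8-fold lower number from compound 1 to compound 4 (0.89 log units; beyond the scatter), so this carbonyl carbon need not carry an alkoxy group for a measurable number in this assay. Amino in place of butoxy gives an at least 7.8-fold lower number from compound 3 to compound 4 (0.89 log units; beyond the scatter), whereas amino in place of propoxy gives a 2.5-fold higher number from compound 2 to compound 4 (0.39 log units; beyond the scatter), so the amino compound stays weaker than the propoxy compound but clear of the limit. Compound 1 and compound 3 remain at a limit: the limit of > 20000 nM in this assay, at which 2 of the 4 values shown sit.

Going by these compounds, whether methylamino or ethoxy on this carbonyl carbon would give a measurable number stays open. So does whether dimethylamino would.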